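Removing the Acetyl Group from an Aryl Amine

The source may hold more compounds than are shown below. What is called first, only, known or untested is meant among the compounds shown, and "the series" means these compounds.

Within the data shown here, compound 2 `CC(=O)Nc1ccc2c(c1)C1CNCC2C1` is the only compound in this set that carries an acetamido substituent on its aromatic ring. In an assay on HEK293 cells for binding affinity to Neuronal acetylcholine receptor; alpha4/beta2 (Homo sapiens) (a lower number here means a stronger inhibitor, a higher number a weaker inhibitor), compound 2 gives 75 nM, the highest of the three numbers measured. Compound 3 `c1nc2cc3c(cc2o1)C1CNCC3C1` gives 0.16 nM in this assay, and compound 1 `c1nc2cc3c(cc2[nH]1)C1CNCC3C1` gives 0.15 nM, both far lower than compound 2 and well beyond the scatter. Compound 4 `Nc1ccc2c(c1)C1CNCC2C1` has not yet been measured; it differs from compound 2 by a single change, (hydrogen in place of acetyl on a nitrogen on an aromatic ring). Among the measured compounds shown here, no measured pair in this set shares that change, so there is no direct precedent for its size. Since compound 3 at 0.16 nM and compound 1 at 0.15 nM both sit so far below compound 2, the step in this assay is expected to move downward by a moderate amount, though with wide uncertainty. Compound 4 is therefore estimated at 20 nM in this assay, within a range of 3 nM to 150 nM. That estimate means a step of a 3.8-fold lower number from compound 2 to compound 4 (0.57 log units; beyond the scatter), expected to lie beyond the scatter.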

Compound 4, inhibition constant: 100 nM
Beside the measured number, compound 4's estimate is 5.0-fold (0.70 log units) below it, within the range that was stated.
By their numbers in this assay, from the lowest: compounds 1 and 3 (each within the scatter of the next); then compounds 2 and 4 (each within the scatter of the next).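

The step is a 1.3-fold higher number from compound 2 to compound 4 (0.12 log units; within the scatter) in this assay, so compound 2 and compound 4 cannot be told apart in this assay. Among these compounds, the earlier compounds offered no pair differing in one place, and this pair gives the first direct reading at this nitrogen on an aromatic ring: going from acetamido to amino removes the acetyl group and its 3 heavy atoms without a step beyond the scatter. Nothing available explains why the two compounds read alike.

On these data alone, it remains open whether other groups on this nitrogen, such as a methyl group, a methanesulfonyl group or a longer acyl chain, would also stay within the scatter of compound 2 and compound 4. This single pair also leaves open whether the same change would behave alike on another core.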